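The source may report more compounds than this note shows. Statements on the series, on what has been measured and on what is new or still open speak of the compounds shown alone.

Of the compounds shown here, three sharing one core have been read in a physicochemical assay for solubility, measured as kinetic solubility; on this read-out lower numbers stand for lower solubility and higher numbers for higher solubility: compound 1 `COc1ccc(S(=O)(=O)Nc2ccc(CN3CCN(C(=O)C4CN(C(C)=O)C4)CC3)cc2)cc1`, compound 2 `COc1ccc(S(=O)(=O)Nc2ccc(CN3CCN(C(=O)C4CCCN(C)C4)CC3)cc2)cc1` and compound 3 `COc1ccc(S(=O)(=O)Nc2ccc(CN3CCN(C(=O)C4CC(O)(C(F)(F)F)C4)CC3)cc2)cc1`. Compound 1 gives >= 511000 nM, which is a limit and not a number. Compound 2 gives >= 526000 nM, again a limit. Compound 3 gives >= 374000 nM, also a limit, so it has no exact place among the three.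

The next compound, compound 4 `COc1ccc(S(=O)(=O)Nc2ccc(CN3CCN(C(=O)Cn4cccnc4=O)CC3)cc2)cc1`, differs from compound 3 in one place: a group of 8 heavy atoms (5 carbon, 2 nitrogen, 1 oxygen; one six-membered aromatic ring with 2 hetero atoms) in place of a group of 9 heavy atoms (5 carbon, 1 oxygen, 3 fluorine; one four-membered non-aromatic ring of carbon only), on a carbonyl carbon. The 3-hydroxy-3-(trifluoromethyl)cyclobutyl group leaves, and the incoming group sits on the same carbonyl carbon, whose other neighbour is an amide-type nitrogen in a ring.

Two measured steps reach the group that now leaves: a step that the two limits leave unreadable from compound 1 to compound 3 and a step that the two limits leave unreadable from compound 2 to compound 3. For the measured compounds named here, neither has a readable size, so they offer no measured step to carry over. All three compounds nevertheless stay at limits in this assay, despite the different groups on that carbonyl carbon. Compound 4 is therefore expected to show no step beyond the scatter and, most likely, to be reported as a limit too. The expected change is a step that the limit leaves unreadable from compound 3 to compound 4. For compound 4 the estimated value is 470000 nM, with an expected range from 250000 nM to 600000 nM.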

Compound 4, solubility: >= 336000 nM
Compound 4 gave a limit, no number; the forecaster's own chance of this, stated with the estimate: 80%; the middle value does not contradict the limit.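

Compound 4, like compound 1, compound 2 and compound 3, stands only at a limit in this assay, so none of the steps from those three compounds to compound 4 can be read. The compounds shown leave open what the actual solubility of any of the four is, and whether the group on the carbonyl carbon changes it at all.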